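A few compounds are considered here, and "the series" means these few. Any claim that something is new, unique, unknown or untested is made for them only; others in the source may bear on it.

Three compounds measured in an assay on isolated protein with Bile acid receptor (Homo sapiens) as the target (on this read-out higher numbers stand for an effect only at larger amounts of compound and lower numbers for an effect already at smaller amounts), set the scene. Compound 1 `COC(=O)/C=C/c1cccc(N(Cc2ccc(-c3cccc(Cl)c3)cc2)C(=O)C(C)C)c1` gives 77 nM. Compound 2 `COC(=O)/C=C/c1cccc(N(Cc2ccc(-c3ccc(C)cc3)cc2)C(=O)NC(C)C)c1` gives 449 nM. Compound 3 `COC(=O)/C=C/c1cccc(N(C(=O)C2CCCCC2)c2ccc3ccccc3c2)c1` gives 680 nM, the highest of the three numbers; its gap to compound 2 lies within the scatter, while its gap to compound 1 lies beyond it, so on these numbers compound 3 needs more substance than compound 1 to reach the same effect.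

Compound 4 `COC(=O)/C=C/c1cccc(N(Cc2cccc(OC)c2)C(=O)C2CCCCC2)c1` has not yet been measured. The change from compound 3 to compound 4 is 3-methoxybenzyl in place of naphthalen-2-yl on an amide-type nitrogen. The amide nitrogen therefore carries a benzyl-type group, as it does in compound 1 and compound 2, instead of a bicyclic aromatic ring attached directly.

Among the compounds with values here, no measured pair differs in only this place, so the size of the step is uncertain. Since compound 1 gives 77 nM and compound 2 gives 449 nM, both with a benzyl-type group on that nitrogen, a lower number than that of compound 3 is expected for compound 4, and the expected step is a 2.3-fold lower number from compound 3 to compound 4 (0.36 log units; beyond the scatter). Compound 4 is estimated at 300 nM, in a range from 80 nM to 1200 nM.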

Compound 4, half-maximal effective concentration: > 1000 nM
Compound 4 was reported as a limit; the forecaster's own chance of this, stated with the estimate: 5%; middle value at least 3.3-fold (0.52 log units) from the limit.
By their numbers in this assay, from the lowest: compound 1; then compounds 2 and 3 (each within the scatter of the next). At a limit, above all of these: compound 4.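

Compound 4 is reported only as a limit: the limit of > 1000 nM in this assay, at which 1 of the 4 values shown sits. Read as a step, the change gives an at least 1.4-fold higher number from compound 3 to compound 4 (0.16 log units; that floor lies within the scatter), and this shows no gain from having 3-methoxybenzyl in place of naphthalen-2-yl on this amide-type nitrogen, though how large the true change is remains unknown. Within the data shown here, this is the first pair that differs at this position alone; compound 1 and compound 2 also carry a benzyl-type group on that nitrogen, but they differ from compound 4 in other places too, and they cannot show what a benzyl-type group does by itself.

From the compounds shown here alone, it remains open whether the methoxy group, the benzyl-type link or the loss of the second aromatic ring matters most, and how a plain benzyl group or a benzyl group carrying a chlorophenyl ring would behave on this nitrogen with the rest of compound 4 kept the same. Going by these compounds, it is also open whether a benzyl group bearing an amine, or a carboxylic acid in place of the methyl ester, would alter the picture at this position.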